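Amide series: chloro in place of trifluoromethyl

This account rests on a few compounds, and the source may have more. Where it says the series, first, only, none or still open, it means among the compounds named here.

Measured so far in a functional assay on NUGC-3 cells (Homo sapiens) for inhibition, read by sulforhodamine B assay, with a stated time of 48 h; a higher number here means a weaker inhibitor of growth, a lower number a stronger inhibitor of growth:

Compound 1 `O=C(Nc1ccc(Cl)cc1)c1nccc2ccccc12` gives > 10000 nM, a limit of the assay.
Compound 2 `O=C(Nc1ccc(C(F)(F)F)cc1)c1nccc2ccccc12` gives > 10000 nM, a limit of the assay.
Compound 3 `O=C(Nc1ccccc1C(F)(F)F)c1nccc2ccccc12` gives > 10000 nM, a limit of the assay.

The step that the two limits leave unreadable from compound 2 to compound 1 is chloro in place of trifluoromethyl on an aromatic carbon; its size cannot be read because of the limit of > 10000 nM in this assay, at which 3 of the 3 values shown sit. Compound 3 and compound 2 share the same atoms joined differently; the difference between the two cores is not broken down here.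

Compound 4 `O=C(Nc1ccccc1Cl)c1nccc2ccccc12` is not yet measured. The change from compound 3 to compound 4 is chloro in place of trifluoromethyl on an aromatic carbon. It is the same kind of change as from compound 2 to compound 1, not the same: there the chloro stands para to a large group, here ortho to a large group.

For this assay the step that the limit leaves unreadable from compound 3 to compound 4 is expected to be small, which rests only on the limits shown for compound 3 > 10000 nM and on (the limit of > 10000 nM in this assay, at which 3 of the 3 values shown sit). Compound 4 is therefore estimated at 20000 nM, most likely again reported as a limit, between 8000 nM and 60000 nM.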

Compound 4, concentration for 50% growth inhibition: > 10000 nM
Compound 4 gave a limit, no number; the forecaster's own chance of this, stated with the estimate: 80%; the middle value does not contradict the limit.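

In this assay, compound 3 and compound 4 both stand only as limits, so no new step can be read for chloro in place of trifluoromethyl between them: the limit of > 10000 nM in this assay, at which 4 of the 4 values shown sit.

The compounds shown leave open how far any of these amides inhibits growth in this assay, since none yet has a value given as a number.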